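The source may report more compounds than this note shows. Statements on the series, on what has been measured and on what is new or still open speak of the compounds shown alone.

Working notes on the series.

Two compounds of this set have numbers in an assay on isolated protein for inhibition of legumain (Mus musculus), read by fluorescence, with stated times of 30 s and 2.5 h; a higher number here means a weaker inhibitor, a lower number a stronger inhibitor. Compound 1 `CCOC(=O)/C=C/C(=O)N(CC(N)=O)NC(=O)[C@@H]1CCCN1C(=O)[C@H]1CSCN1C(C)=O` gives 167 nM in this assay. Compound 2 `CCOC(=O)/C=C/C(=O)N(CC(N)=O)NC(=O)[C@@H]1CCCN1C(=O)C(C)(C)NC(C)=O` gives 198 nM in this assay. Among the measured compounds shown here, the one step between them, a 1.2-fold higher number from compound 1 to compound 2 (0.07 log units; within the scatter), exchanges the group on the carbonyl carbon attached to the amide-type nitrogen in the ring. For the measured compounds named here, on the numbers so far, compound 2 carries the highest of the two values, but its nearest neighbour is compound 1 and the gap between them lies within the scatter, so no order between the two can be claimed.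

Compound 3 `CCOC(=O)/C=C/C(=O)N(CC(N)=O)NC(=O)[C@@H]1CCCN1C(=O)C(NC(C)=O)=C(C)C` is not yet measured. Its difference from compound 2 is a group of 8 heavy atoms (6 carbon, 1 nitrogen, 1 oxygen; no ring) in place of a group of 7 heavy atoms (5 carbon, 1 nitrogen, 1 oxygen; no ring), on a carbonyl carbon. The group that enters has no common name; it carries 2 double bonds outside aromatic rings where the 1-acetamido-1-methylethyl group that leaves carries 1. Going by the values given here, the only measured step that bears on this position is a 1.2-fold higher number from compound 1 to compound 2 (0.07 log units; within the scatter), which stayed within the scatter. Nothing measured points to a move beyond the scatter, so the step of a 1.0-fold higher number from compound 2 to compound 3 (0.00 log units; within the scatter) is expected to be small. Compound 3 is estimated at 200 nM in this assay, within a range of 90 nM to 450 nM.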

Compound 3, half-maximal inhibitory concentration: 148 nM
The estimate for compound 3 lay 1.4-fold (0.13 log units) above the measured number; the measured number falls inside the stated range.
By their numbers in this assay, from the lowest: compounds 3, 1 and 2 (each within the scatter of the next).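

The exchange on the carbonyl carbon whose other neighbours are the amide-type nitrogen in a ring now has a second open-chain reading in this assay: the entering group, with 2 double bonds outside aromatic rings in place of 1, gives a step that stays small (a 1.3-fold lower number from compound 2 to compound 3 (0.13 log units; within the scatter)). Among the compounds shown here, the same group set against the ring-bearing group of compound 1 also stays small (a 1.1-fold lower number from compound 1 to compound 3 (0.05 log units; within the scatter)), so three different groups at this place, one with a five-membered ring and two without a ring, now sit within the scatter of one another, and no compound of the three goes against this. No measurement on the series explains why these groups read alike, and no cause can be given for this result.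

It remains open whether any group on this carbonyl carbon can move the number beyond the scatter, since all three groups shown carry an acetyl-capped nitrogen. An amine or a carboxylic acid at this place, or a longer chain in place of the acetyl, would test how far this reading holds.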